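The source may hold more compounds than are shown below. What is called first, only, known or untested is meant among the compounds shown, and "the series" means these compounds.

Compound 1 `Cc1ccc(C(=O)CSc2nnc(C)n2N2C(=O)c3ccccc3C2=O)cc1` carries a (4-methylphenyl)carbonyl on a saturated chain carbon bound to a sulfur. In a functional assay on HepG2 cells (Homo sapiens) for cytotoxicity, read by MTT assay, with a stated time of 48 h (on this read-out higher numbers stand for weaker inhibition and lower numbers for stronger inhibition), compound 1 gives only a limit, > 200000 nM. Compound 2 `CSc1nnc(C)n1N1C(=O)c2ccccc2C1=O` lacks that group: hydrogen in place of (4-methylphenyl)carbonyl on a saturated chain carbon bound to a sulfur. In this assay compound 2 likewise gives only a limit, > 200000 nM. The step that the two limits leave unreadable from compound 1 to compound 2 therefore has no readable size, because of the limit of > 200000 nM in this assay, at which 3 of the 3 values shown sit. Compound 3 `CCc1nnc(SCC(=O)c2ccc(C)cc2)n1N1C(=O)c2ccccc2C1=O` has a different core from compound 1, the difference being (methyl in place of hydrogen on a saturated chain carbon bound to an aromatic carbon). In this assay compound 3 again gives only a limit, > 200000 nM. The step that the two limits leave unreadable from compound 1 to compound 3 is unreadable for the same reason, because of the limit of > 200000 nM in this assay, at which 3 of the 3 values shown sit.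

Compound 4 `CCc1nnc(SC)n1N1C(=O)c2ccccc2C1=O` has not yet been measured. For the measured compounds named here, it differs from compound 3 by hydrogen in place of (4-methylphenyl)carbonyl on a saturated chain carbon bound to a sulfur, which is the same change, at the same place, as the one from compound 1 to compound 2. Compounds 2 and 4 share the absence of that group and differ from each other only as compounds 1 and 3 do. Since the measured step that the two limits leave unreadable from compound 1 to compound 2 gave no readable change, the step that the limit leaves unreadable from compound 3 to compound 4 is expected to be of about that same unreadable kind. Compound 4 is therefore expected to give 300000 nM, with a plausible range from 150000 nM to 1000000 nM, most likely reported once more as a limit rather than a number.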

Compound 4, half-maximal inhibitory concentration: > 200000 nM
Compound 4: a limit, no number (the forecaster's own chance of this, stated with the estimate: 85%); the middle value does not contradict the limit.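

Compound 4 also gives only a limit, not a number, so the steps from compound 3 to compound 4 and from compound 2 to compound 4 have no readable size, because all four compounds end at the same limit: the limit of > 200000 nM in this assay, at which 4 of the 4 values shown sit.

The compounds shown leave open whether replacing the (4-methylphenyl)carbonyl with hydrogen, or adding the methyl, makes any difference at all in this assay.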